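A few compounds are considered here, and "the series" means these few. Any claim that something is new, unique, unknown or untested is made for them only; others in the source may bear on it.

Measured in a functional assay on cells (T-cell line, Homo sapiens) for inhibition; a higher number here means a weaker inhibitor, a lower number a stronger inhibitor:

Compound 1 `COc1ccc(CCCN2CCC(CO)CC2)cc1`: > 20000 nM
Compound 2 `Cc1ccc(CCCN2CCC(COC(c3ccccc3)c3ccccc3)CC2)cc1`: 200 nM

The entry for compound 1 is a limit of this assay, not a number. Among the compounds with values here, compound 2 gives 200 nM, the only true number so far, so there is no measured series against which to rank it.

The next compound is compound 3 `Clc1ccccc1CCCN1CCC(COC(c2ccccc2)c2ccccc2)CC1`. It has 2-chlorophenyl in place of 4-methylphenyl on a saturated chain carbon, three bonds along the chain from an amine nitrogen in a ring. The rest of the structure stays as in compound 2, which reads 200 nM, and that value is the natural starting point. Within the data shown here, no measured step shows what this swap does. The estimated step of a 1.3-fold higher number from compound 2 to compound 3 (0.10 log units; within the scatter) is therefore expected to stay within the usual scatter, with no favoured direction. Compound 3 is expected at 250 nM, with an estimated range of 80 nM to 800 nM.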

Compound 3, half-maximal inhibitory concentration: 800 nM
For compound 3 the middle estimate is 3.2-fold (0.51 log units) below the measured one, within the range that was stated.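

In this assay, within the data shown here, putting 2-chlorophenyl in place of 4-methylphenyl gives a 4.0-fold higher number from compound 2 to compound 3 (0.60 log units; beyond the scatter), the first measured step. It shows that this spot on a saturated chain carbon, three bonds along the chain from an amine nitrogen in a ring, is not indifferent to the ring it carries, even though both groups have the same count of heavy atoms. Compound 3 is a weaker inhibitor than compound 2, yet it still gives a true number, and nothing measured here explains the size of this step.

The swap changes both the substituent and where it sits on the ring, and these two compounds cannot separate those effects. From the compounds shown here alone, how 4-chlorophenyl or 2-methylphenyl would read stays open, as does the effect of a plain phenyl group or a longer chain.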